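This account rests on a few compounds, and the source may have more. Where it says the series, first, only, none or still open, it means among the compounds named here.

Three compounds of a shared core carry different substituents on the benzylic aromatic ring. Compound 1 `O=[N+]([O-])c1cn2c(n1)OC[C@@H](NCc1ccc(OC(F)(F)F)c(F)c1)C2` gives 58.7 mL.min-1.g-1 in an in vitro ADME assay on the whole organism (microsomes, liver, Mus musculus) for metabolic stability, read by LC-MS, with a stated time of 24 h, at a dose of 5 mg/kg by the intravenous route; on this read-out higher numbers stand for fast clearance and lower numbers for slow clearance. Compound 2 `O=[N+]([O-])c1cn2c(n1)OC[C@@H](NCc1ccc(OC(F)(F)F)cc1Cl)C2` gives 69.7 mL.min-1.g-1 in this assay, a number that sits within the scatter of compound 1 and beyond the scatter below compound 3 `O=[N+]([O-])c1cn2c(n1)OC[C@@H](NCc1ccc(OC(F)(F)F)c(Oc3ccccc3)c1)C2`, which gives 149 mL.min-1.g-1 in this assay and stands highest of the three. Among the compounds with values here, the one single-change step among them is a 2.5-fold higher number from compound 1 to compound 3 (0.40 log units; beyond the scatter), where an aryl ether replaces a halogen on the aromatic ring.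

Compound 4 `O=[N+]([O-])c1cn2c(n1)OC[C@@H](NCc1ccc(OC(F)(F)F)cc1OC1CC1)C2` has not yet been measured in this assay. Relative to compound 2 it shows (cyclopropyloxy in place of chloro on an aromatic carbon). Here too an ether oxygen replaces a halogen on the aromatic ring, so the step from compound 1 to compound 3 is the one that bears on it, and a modest rise in the same direction is expected, because a 2.5-fold higher number from compound 1 to compound 3 (0.40 log units; beyond the scatter) went beyond the scatter. The expected step is a 1.6-fold higher number from compound 2 to compound 4 (0.22 log units; within the scatter). Compound 4 is therefore estimated at 115 mL.min-1.g-1 in this assay, within a range of 60 mL.min-1.g-1 to 220 mL.min-1.g-1.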

Compound 4, intrinsic clearance in microsomes in the liver assay: 151 mL.min-1.g-1
Compound 4: middle estimate off by 1.3-fold (0.12 log units), on the low side; the measured number falls inside the stated range.
By their numbers in the liver assay, from the lowest: compounds 1 and 2 (each within the scatter of the next); then compounds 3 and 4 (each within the scatter of the next).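

With cyclopropyloxy in place of chloro on this aromatic carbon, ortho to a large group and meta to a trifluoromethoxy group, the liver assay shows a 2.2-fold higher number from compound 2 to compound 4 (0.34 log units; beyond the scatter), so both ether-for-halogen steps shown now point upward beyond the scatter, though at different places on the ring. The earlier compounds shown here gave no reading at this place and none on solubility: in a physicochemical assay for solubility, at pH 6.8 (a lower number here means a less soluble compound, a higher number a more soluble compound), compound 2 gives 30 ug/mL and compound 4 gives 11 ug/mL. Within the data shown here, the one change thus raises the number in the liver assay and lowers it in the physicochemical assay, with a 2.7-fold lower number from compound 2 to compound 4 (0.44 log units; beyond the scatter).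

The compounds shown leave open whether these steps follow the ether oxygen or the three-membered ring, which a methoxy group at this place would help to separate. From the compounds shown here alone, whether an amine here would move the two read-outs differently also remains open.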